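From but-1-en-1-yl to chloromethyl on the carbonyl carbon

The compounds below may be only part of what the source reports. "The series", "measured", "known", "first", "only" and "open" are said of these compounds alone.

In a functional assay on MGC-803 cells (Homo sapiens) for inhibition, read by MTT assay, with a stated time of 48 h (on this read-out higher numbers stand for weaker inhibition and lower numbers for stronger inhibition), compound 3 `CC/C=C/C(=O)N(Cc1ccc(OC)c(O)c1)c1cc(OC)c(OC)c(OC)c1` gives 58 nM, and compound 2 `CCC/C=C/C(=O)N(Cc1ccc(OC)c(O)c1)c1cc(OC)c(OC)c(OC)c1` gives 70 nM. These two stand level, with a 1.2-fold lower number from compound 2 to compound 3 (0.08 log units; within the scatter). Compound 1 `COc1ccc(CN(C(=O)C=C(C)C)c2cc(OC)c(OC)c(OC)c2)cc1O` gives 320 nM and is the weakest of the three, as shown by a 5.5-fold lower number from compound 1 to compound 3 (0.74 log units; beyond the scatter) and a 4.6-fold lower number from compound 1 to compound 2 (0.66 log units; beyond the scatter).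

The next compound, compound 4 `COc1ccc(CN(C(=O)CCl)c2cc(OC)c(OC)c(OC)c2)cc1O`, differs from compound 3 at the acyl group: chloromethyl in place of but-1-en-1-yl on a carbonyl carbon. In words, this is chloromethyl in place of but-1-en-1-yl on a carbonyl carbon.

All three measured steps fall on this same carbonyl carbon, but each only exchanges one alkenyl group for another. The two modest steps from compound 1 show that the number in this assay can move with the group at this place. The step between compound 2 and compound 3 stays within the scatter. Within the data shown here, no measured compound carries a chlorine-bearing or saturated group here, so none of these steps transfers directly. The modest steps serve only as a rough guide to size, and they leave either direction open. A small rise is expected, not clearly beyond the scatter, with the expected step being a 1.7-fold higher number from compound 3 to compound 4 (0.24 log units; within the scatter). For compound 4 the estimated value is 100 nM, with an expected range of 25 nM to 400 nM.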

Compound 4, half-maximal inhibitory concentration: 84 nM
For compound 4 the middle estimate is 1.2-fold (0.08 log units) above the measured one; low and high end bracket the measured number.
By their numbers in this assay, from the lowest: compounds 3, 2 and 4 (each within the scatter of the next); then compound 1.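

In this assay the chloromethyl group on the carbonyl carbon stands level with both but-1-en-1-yl (a 1.4-fold higher number from compound 3 to compound 4 (0.16 log units; within the scatter)) and pent-1-en-1-yl (a 1.2-fold higher number from compound 2 to compound 4 (0.08 log units; within the scatter)), even though it has 2 heavy atoms, one of them chlorine, and no double bond outside aromatic rings. Among the compounds shown, a double bond in this group is therefore not needed for a number in this range, and the acyl group can change in both size and atom type with no step beyond the scatter; compound 1 alone stands apart, since the 2-methylprop-1-en-1-yl group also gives a clearly higher number against chloromethyl (a 3.8-fold lower number from compound 1 to compound 4 (0.58 log units; beyond the scatter)). No measured evidence bears on the reason for this level result.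

Open, on these data alone, is whether a plain methyl group or a propyl chain on the carbonyl carbon would stay level with chloromethyl, which would show whether the chlorine has any bearing on the number. Also open, as far as these compounds go, are bromomethyl, aminomethyl and a carboxylic acid at this place, and whether any of them would stay level with compound 4 or move towards compound 1.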